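Swapping pyridin-4-yl for 2-chlorophenyl on the shared core

A few compounds are considered here, and "the series" means these few. Any claim that something is new, unique, unknown or untested is made for them only; others in the source may bear on it.

Two compounds have been measured so far in a functional assay on MOLT-4 cells (Homo sapiens) for antiproliferative activity (on this read-out lower numbers stand for stronger inhibition and higher numbers for weaker inhibition), and they give these values:

- compound 1 `COc1cc(C(=O)c2sc(-c3ccc(I)cc3)cc2N)cc(OC)c1OC` at 190 nM
- compound 2 `COc1cc(C(=O)c2sc(-c3ccncc3)cc2N)cc(OC)c1OC` at 88 nM

Compound 2 holds the lower of these two numbers and is thus the stronger inhibitor of the pair. The next compound, compound 3 `COc1cc(C(=O)c2sc(-c3ccccc3Cl)cc2N)cc(OC)c1OC`, has not yet been measured. It differs from compound 2 as follows: 2-chlorophenyl in place of pyridin-4-yl on an aromatic carbon, which puts 2-chlorophenyl in place of pyridin-4-yl next to the ring sulfur. Within the data shown here, only one measured step bears on this change, namely a 2.2-fold lower number from compound 1 to compound 2 (0.33 log units; beyond the scatter) with pyridin-4-yl in place of 4-iodophenyl on an aromatic carbon. That step was modest, and it is a thin guide since the two groups on the carbon-only ring differ. Compound 1 at 190 nM is still the closest comparison for compound 3. A modest move toward a higher number is therefore expected in this assay, and the estimated step is a 2.2-fold higher number from compound 2 to compound 3 (0.33 log units; beyond the scatter) overall. For compound 3 the estimated value is 190 nM (expected range 60 nM to 600 nM).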

Compound 3, half-maximal inhibitory concentration: 17 nM
Estimate against measurement, compound 3: 11-fold (1.05 log units) above, outside the stated range (below it).
By their numbers in this assay, from the lowest: compound 3; then compound 2; then compound 1.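

In this assay, 2-chlorophenyl on the aromatic carbon next to the ring sulfur gives a 5.2-fold lower number from compound 2 to compound 3 (0.71 log units; beyond the scatter) when it replaces pyridin-4-yl, and an 11-fold lower number from compound 1 to compound 3 (1.05 log units; beyond the scatter) when it replaces 4-iodophenyl, and both steps lie beyond the scatter. The earlier pair showed only that pyridin-4-yl stood with a lower number than 4-iodophenyl, whereas compound 3 and compound 1 both carry a ring of carbon only and yet stand at opposite ends of the three, with compound 2 between them, so the presence of ring nitrogen alone does not set the order at this position. Nothing available accounts for these differences.

The 2-chlorophenyl and 4-iodophenyl groups differ both in their halogen and in where it stands on the ring, so the compounds shown cannot separate those two changes. Also open, as far as these compounds go, is how a plain phenyl group would compare, and whether a methyl or methoxy group in place of the chlorine of 2-chlorophenyl would keep compound 3's low number.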